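The compounds below may be only part of what the source reports. "The series", "measured", "known", "first", "only" and "open" are said of these compounds alone.

Working notes on the series, which shares one core and differs only at a carbonyl carbon. In a physicochemical assay for lipophilicity, read by HPLC, measured as octanol-water partition, with a stated time of 24 h, at pH 7.4 (a lower number here means a more polar compound, a higher number a more lipophilic compound), compound 2 `CCNC(=O)c1cc(N)c(Nc2ccc(C#N)cc2)cc1Oc1c(C)cc(/C=C/C#N)cc1C` gives 3.63, the highest of the two numbers in hand. Compound 3 `Cc1cc(/C=C/C#N)cc(C)c1Oc1cc(Nc2ccc(C#N)cc2)c(N)cc1C(=O)N1CC1` gives 2.21 in this assay, and the step is a number 1.42 log units lower from compound 2 to compound 3 (beyond the scatter). Compound 1 `COCCOC(=O)c1cc(N)c(Nc2ccc(C#N)cc2)cc1Oc1c(C)cc(/C=C/C#N)cc1C` gives > 5 in this assay; this is the limit of > 5 in this assay, at which 1 of the 3 values shown sits, not a number. Even so, a number at least 1.37 log units lower from compound 1 to compound 2 (beyond the scatter) and a number at least 2.79 log units lower from compound 1 to compound 3 (beyond the scatter). Compound 4 `COC(=O)c1cc(N)c(Nc2ccc(C#N)cc2)cc1Oc1c(C)cc(/C=C/C#N)cc1C` carries the change (methoxy in place of ethylamino on a carbonyl carbon). Within the data shown here, no measured step makes this exact move, but the two steps away from the 2-methoxyethoxy of compound 1 are large and downward, so the reverse direction, toward methoxy, is expected to raise the number well beyond the scatter. Compound 4 is expected at 4.6, between 4 and 5.2, and the step is expected to be a number 0.97 log units higher from compound 2 to compound 4 (beyond the scatter).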

Compound 4, partition coefficient: 4.15
Estimate against measurement, compound 4: 0.45 log units above; low and high end bracket the measured number.
By their numbers in this assay, from the lowest: compound 3; then compound 2; then compound 4. At a limit, above all of these: compound 1.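

In this assay, compound 4 gives a number, not a limit, for a group bound through oxygen at this carbonyl carbon. Ethylcarbamoyl to methoxycarbonyl is a modest move, a number 0.52 log units higher from compound 2 to compound 4 (beyond the scatter), while replacing aziridin-1-yl with methoxy gives a larger one, a number 1.94 log units higher from compound 3 to compound 4 (beyond the scatter). Replacing 2-methoxyethoxy with methoxy gives only a bound, a number at least 0.85 log units lower from compound 1 to compound 4 (beyond the scatter), and compound 1 stands at a limit: the limit of > 5 in this assay, at which 1 of the 4 values shown sits.

Going by these compounds, the size of that last step stays open. So does the place of a carboxylic acid or a propoxy chain at this carbonyl carbon within the order shown.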